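Amide for fluoro: the next step from compound 2

The source may hold more compounds than are shown below. What is called first, only, known or untested is meant among the compounds shown, and "the series" means these compounds.

Measured so far, in an assay for inhibition of serine/threonine-protein kinase PLK2 (Homo sapiens), read by FRET and Z'-LYTE, with a stated time of 1 h; a higher number here means a weaker inhibitor, a lower number a stronger inhibitor:
- compound 1, `CCC1C(=O)N(C)c2cnc(Nc3ccc(S(=O)(=O)NCC(C)C)cc3)nc2N1c1ccn(C)n1`, gives 311 nM
- compound 2, `CC[C@@H]1C(=O)N(C)c2cnc(-n3ccc4cc(F)ccc43)nc2N1C1CCCC1`, gives 969 nM
- compound 3, `CCCNC(=O)c1ccc2c(ccn2-c2ncc3c(n2)N(c2ccn(C)n2)C(CC)C(=O)N3C)c1`, gives 207 nM

Compound 2 has the highest number of the three in this assay. Its nearest neighbour on the numbers is compound 1, which sits lower by a gap beyond the scatter; compound 3 sits lower still, also beyond the scatter. None of these three differs from another in one place only, so the gaps say nothing about a single change.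

The next compound, compound 4, `CC[C@@H]1C(=O)N(C)c2cnc(-n3ccc4cc(C(=O)NC5CCCC5)ccc43)nc2N1C1CCCC1`, is compound 2 with one change: cyclopentylcarbamoyl in place of fluoro on an aromatic carbon. Going by the values given here, no measured pair shows this change on its own. Compound 3 carries a propylcarbamoyl group on a related fused ring and gives 207 nM in this assay, but its other substituents differ from those of compound 2, so it offers only a loose hint.

On that basis compound 4 is expected to give a lower number than compound 2, by a step of moderate size, a 2.4-fold lower number from compound 2 to compound 4 (0.38 log units; beyond the scatter), with real uncertainty. The estimate for compound 4 in this assay is 400 nM, within a range from 150 nM to 1200 nM.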

Compound 4, half-maximal inhibitory concentration: 7.06 nM
Estimate against measurement, compound 4: 57-fold (1.75 log units) above, and the stated range ends above it.
By their numbers in this assay, from the lowest: compound 4; then compounds 3 and 1 (each within the scatter of the next); then compound 2.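

In this assay, going by these compounds alone, cyclopentylcarbamoyl in place of fluoro on an aromatic carbon gives a 140-fold lower number from compound 2 to compound 4 (2.14 log units; beyond the scatter), the first step that isolates a single change. This position on the six-membered aromatic ring of carbon only therefore accepts a much larger group, with 8 heavy atoms entering where 1 leaves, along with 1 hydrogen-bond donor, 1 hydrogen-bond acceptor and a five-membered non-aromatic ring, and the number falls sharply rather than rises. No measurement available on this series gives a reason for the step.

The change replaces everything at this carbon at once, so the contributions of the carbonyl, the amide hydrogen and the cyclopentyl ring cannot be told apart, and a carboxylic acid, an unsubstituted carbamoyl or a cyclopropylcarbamoyl at the same carbon would begin to separate them. Compound 3 carries propylcarbamoyl but differs from compound 4 in more than one place, so the open-chain amide against the ring remains unresolved, as does whether the same change would give a step of similar size on other members of the series.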